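Moving One Fluorine on a Benzyl Group

The compounds below may be only part of what the source reports. "The series", "measured", "known", "first", "only" and "open" are said of these compounds alone.

In a functional assay on 4T1 cells (Mus musculus) for cytotoxicity, read by MTT assay, with a stated time of 24 h (on this read-out higher numbers stand for weaker inhibition and lower numbers for stronger inhibition), compound 1 (`COc1ccc(/C=C2\CN(C(=S)SCc3cn(Cc4ccccc4F)nn3)C/C(=C\c3ccc(OC)cc3)C2=O)cc1`) gives 49900 nM. Compound 2 (`COc1ccc(/C=C2\CN(Cc3cn(Cc4cccc(Cl)c4)nn3)C/C(=C\c3ccc(OC)cc3)C2=O)cc1`) gives 56600 nM. Compound 1 has the lowest number of the two, but the pair lies within the usual scatter of repeated measurements, so the two cannot be told apart on this evidence. Both numbers are the half-maximal inhibitory concentration.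

Compound 3 (`COc1ccc(/C=C2\CN(C(=S)SCc3cn(Cc4ccc(F)cc4)nn3)C/C(=C\c3ccc(OC)cc3)C2=O)cc1`) has not yet been measured. It keeps the atoms of compound 1 but joins them differently: 4-fluorophenyl in place of 2-fluorophenyl on a saturated chain carbon bound to an aromatic nitrogen. In words, 4-fluorophenyl stands in place of 2-fluorophenyl on a saturated chain carbon bound to an aromatic nitrogen, which turns 2-fluorobenzyl into 4-fluorobenzyl.

Among the compounds with values here, no measured pair here differs in one place only, so the data show no direct precedent for this change. The expectation therefore starts from compound 1 at 49900 nM, and no step beyond the scatter is foreseen in this assay, in either direction. The expected step is a 1.0-fold higher number from compound 1 to compound 3 (0.00 log units; within the scatter). For compound 3 the estimated value is 50000 nM, with an expected range from 25000 nM to 100000 nM.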

Compound 3, half-maximal inhibitory concentration: > 100000 nM
Compound 3: only a limit was reported (the forecaster's own chance of this, stated with the estimate: 10%); at least 2.0-fold (0.30 log units) between middle value and limit.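

For compound 3 the reading in this assay is a limit and not a number: the limit of > 100000 nM in this assay, at which 1 of the 3 values shown sits.

Compounds 1 and 3 are the one pair shown that differs in a single place, with the same atoms joined differently, so this is the only direct test of the change from 2-fluorobenzyl to 4-fluorobenzyl on a saturated chain carbon bound to an aromatic nitrogen. That change gives an at least 2.0-fold higher number from compound 1 to compound 3 (0.30 log units; that floor lies within the scatter), and since this figure is only a floor, the true step could be that small or far larger, so the pair cannot show whether the place of the fluorine on this benzyl group matters much or little.

Still open, on these data alone, is how a plain benzyl group with no fluorine, a 3-fluorobenzyl group or a 4-aminobenzyl group on the same carbon would read in this assay, any of which would help to show whether compound 1 or compound 3 is the unusual one. Also open, as far as these compounds go, is the actual number for compound 3, which would turn this floor into a measured step.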